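The compounds below may be only part of what the source reports. "The series", "measured", "known", "first", "only" and "open" are said of these compounds alone.

Measured so far:
compound 1, `COc1cc(/C=C/C(=O)c2cccc(NC(=O)c3ccc(Cl)cc3)c2)ccc1O`: 2.3 ug/mL
compound 2, `COc1cc(/C=C/C(=O)c2cccc(NC(=O)c3ccc(Cl)c(Cl)c3)c2)ccc1O`: 25.3 ug/mL

In a functional assay on SiHa cells (Homo sapiens) for inhibition (on this read-out lower numbers stand for stronger inhibition and higher numbers for weaker inhibition), compound 1 stands lowest of these two numbers; compound 2 lies an 11-fold higher number from compound 1 to compound 2 (1.04 log units; beyond the scatter) away. Compound 3, `COC(=O)C(=O)Nc1cccc(C(=O)/C=C/c2ccc(O)c(OC)c2)c1`, is not yet measured. It differs from compound 1 as follows: methoxycarbonyl in place of 4-chlorophenyl on a carbonyl carbon. Within the data shown here, the only measured step, an 11-fold higher number from compound 1 to compound 2 (1.04 log units; beyond the scatter), concerns a chloro on an aromatic carbon, not the exchange of a whole 4-chlorophenyl group for methoxycarbonyl, so it bears on the new change only loosely. A weakening beyond the scatter is expected, since compound 1 is the stronger of the two known compounds, giving an expected 3.5-fold higher number from compound 1 to compound 3 (0.54 log units; beyond the scatter). Compound 3 is estimated at 8 ug/mL, between 2 ug/mL and 32 ug/mL.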

Compound 3, half-maximal inhibitory concentration: 7.71 ug/mL
Beside the measured number, compound 3's estimate is 1.0-fold (0.02 log units) above it; the measured number falls inside the stated range.
By their numbers in this assay, from the lowest: compound 1; then compound 3; then compound 2.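

In this assay, the aryl group on this carbonyl carbon can be replaced by a group with no ring and inhibition remains: methoxycarbonyl gives a 3.4-fold higher number from compound 1 to compound 3 (0.53 log units; beyond the scatter) in place of 4-chlorophenyl and a 3.3-fold lower number from compound 2 to compound 3 (0.52 log units; beyond the scatter) in place of 3,4-dichlorophenyl. The same new group therefore moves the number up or down, depending on which aryl group it replaces. Nothing available explains these shifts. The compounds shown leave open whether the methyl ester itself matters, as a carboxylic acid or a primary amide at this place would show.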